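Changing the Ring on the Triazole Nitrogen in Lung Cells

The source may report more compounds than this note shows. Statements on the series, on what has been measured and on what is new or still open speak of the compounds shown alone.

Measured compounds:
- compound 1, `COc1ccc(/C=C\C(=O)O)c(OCc2cn(-c3ccc(NC(=O)c4ccccc4)cc3)nn2)c1CC=C(C)C`: 42700 nM
- compound 2, `COc1ccc(/C=C\C(=O)O)c(OCc2cn(-c3ccccc3F)nn2)c1CC=C(C)C`: "not determined" (no result reported)
- compound 3, `COc1ccc(/C=C\C(=O)O)c(OCc2cn(-c3cccc(C#N)c3)nn2)c1CC=C(C)C`: "not determined" (no result reported)

In a functional assay on A549 cells (Homo sapiens) for cytotoxicity, read by MTT assay, with a stated time of 24 h (on this read-out lower numbers stand for stronger inhibition and higher numbers for weaker inhibition), only compound 1 gives a number, 42700 nM. Compound 3 stands without a value there, as does compound 2, so compound 3 cannot be placed against compound 1 on the numbers.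

Compound 4, `COc1ccc(/C=C\C(=O)O)c(OCc2cn(-c3nc4ccccc4s3)nn2)c1CC=C(C)C`, differs from compound 3 in one place: 1,3-benzothiazol-2-yl in place of 3-cyanophenyl on an aromatic nitrogen. Among the measured compounds shown here, no measured pair shows what a change of this kind does, so neither size nor direction of a step from compound 3 can be drawn from the data; the expectation is that compound 4 stays near where compound 1 stands, with no step beyond the scatter foreseen.

Compound 4 is estimated at 40000 nM, with a range from 10000 nM to 150000 nM.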

Compound 4, half-maximal inhibitory concentration: 42100 nM
Beside the measured number, compound 4's estimate is 1.1-fold (0.02 log units) below it, within the range that was stated.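

Compound 3 has no number to set against compound 4 in this assay, so no step can be read between them. How the ring on the triazole nitrogen affects this read-out stays open, and no evidence is at hand to explain the value of compound 4.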